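This account rests on a few compounds, and the source may have more. Where it says the series, first, only, none or still open, it means among the compounds named here.

Measured so far:
compound 1 `Nc1ccccc1NC(=O)c1ccc(CSC(=S)N2CCN(c3ccc(Cl)cc3)CC2)cc1` – 44.8%
compound 2 `Nc1ccccc1NC(=O)c1ccc(CSC(=S)N2CCc3ccccc32)cc1` – 67%

Two compounds have been run in a functional assay on HeLa cells (Homo sapiens) for antiproliferative activity, read by CCK-8 assay, with a stated time of 72 h, tested at 8 uM; on this read-out higher numbers stand for a stronger effect at the one concentration tested and lower numbers for a weaker effect. Compound 2 gives 67% and compound 1 gives 44.8%, so compound 2 stands highest of the two, and its gap to compound 1 lies beyond the scatter. For the measured compounds named here, no measured pair differs in a single place, so no single-step change has been sized yet.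

Compound 3 `CN(Cc1ccncc1)C(=S)SCc1ccc(C(=O)Nc2ccccc2N)cc1` is the next candidate for this assay. It differs from compound 2 in one place: methyl((pyridin-4-yl)methyl)amino in place of 2,3-dihydro-1H-indol-1-yl on a thiocarbonyl carbon. The leaving and entering groups are counted to the same number of heavy atoms, but the entering group brings one hydrogen-bond acceptor where the leaving group brought none.

Without a measured single-place step to lean on, the expected step is a moderate drop, beyond the scatter, as given by a number 17 percentage points lower from compound 2 to compound 3 (beyond the scatter). Compound 3 is estimated at 50%, with a range from 25% to 75%.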

Compound 3, a percentage reported as inhibition, at one concentration (the size of the read-out at that concentration, not a potency): 72.7%
The estimate for compound 3 lay 22.7 percentage points below the measured number; the measured number falls inside the stated range.
By their numbers in this assay, from the lowest: compound 1; then compounds 2 and 3 (each within the scatter of the next).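

In this assay, methyl((pyridin-4-yl)methyl)amino in place of 2,3-dihydro-1H-indol-1-yl on a thiocarbonyl carbon gives a number 5.7 percentage points higher from compound 2 to compound 3 (within the scatter), the first single-place step sized in this series. This place on the thiocarbonyl carbon therefore accepts a six-membered aromatic ring with 1 hetero atom and a hydrogen-bond acceptor in the entering group, in place of the leaving group's two-ring unit, with the read-out staying within the scatter. No measurement on hand accounts for this result.

On these data alone, it remains open whether the pyridine nitrogen contributes at all, which a benzyl group in place of the (pyridin-4-yl)methyl group would test. Also open is how a smaller group such as dimethylamino or a morpholine ring would read at this place, and how any of these compounds compare in potency beyond the one concentration tested.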